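Fluoro for Methoxy on the Aryl Group of a Shared Core

The compounds below may be only part of what the source reports. "The series", "measured", "known", "first", "only" and "open" are said of these compounds alone.

Measured compounds:
compound 1, `Clc1ccc(-c2cn3ccnc3c(-c3ccc4ncn(C5CCCCC5)c4c3)n2)cc1`, giving 4.11% in a functional assay on NCI-H23 cells (Homo sapiens) for inhibition, read by sulforhodamine B assay, with a stated time of 48 h, tested at 10 uM; a higher number here means more inhibition at the concentration tested (going by the name of the read-out), a lower number less inhibition
compound 2, `COc1ccccc1-c1cn2ccnc2c(-c2ccc3ncn(C4CCCCC4)c3c2)n1`, giving 2.79%

Both measured compounds share one core and differ only in the aryl group attached to it. For the measured compounds named here, compound 2 holds the lower of the two numbers, but the only measured step, a number 1.3 percentage points lower from compound 1 to compound 2 (within the scatter), sits within the scatter, so the two cannot be told apart on this assay. Compound 3, `Fc1ccccc1-c1cn2ccnc2c(-c2ccc3ncn(C4CCCCC4)c3c2)n1`, is reached from compound 2 by the change (fluoro in place of methoxy on an aromatic carbon). Going by the values given here, the one step that bears on it, a number 1.3 percentage points lower from compound 1 to compound 2 (within the scatter), exchanged the whole aryl group and still produced no movement beyond the scatter; it gives no reason to expect that swapping one small substituent for another will do more. Compound 3 is therefore expected to give about 4%, with a range from -6% to 14%. The estimated step of a number 1.2 percentage points higher from compound 2 to compound 3 (within the scatter) is expected to stay within the scatter.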

Compound 3, a percentage reported as inhibition, at one concentration (the size of the read-out at that concentration, not a potency): 4.16%
The estimate for compound 3 lay 0.2 percentage points below the measured number; the measured number falls inside the stated range.
By their numbers in this assay, from the lowest: compounds 2, 1 and 3 (each within the scatter of the next).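

In this assay, exchanging methoxy for fluoro on an aromatic carbon ortho to a large group, a change confined to one small substituent that removes the hydrogen-bond acceptor of the methoxy, gave a number 1.4 percentage points higher from compound 2 to compound 3 (within the scatter) and so left the number unmoved beyond the scatter. The wider exchange gave a number 0.1 percentage points higher from compound 1 to compound 3 (within the scatter) with 2-fluorophenyl in place of 4-chlorophenyl, so the three aryl groups shown cannot be told apart in this read-out. No independent data on these compounds offer an explanation for this result.

From the compounds shown here alone, whether an amine or a carboxylic acid at this position would give a step beyond the scatter remains open. So does whether a longer chain in place of fluoro or methoxy would do so.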